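Carbonyl in place of sulfonyl on the aromatic nitrogen

This account rests on a few compounds, and the source may have more. Where it says the series, first, only, none or still open, it means among the compounds named here.

Measured so far:
compound 1 `CC(C)c1onc(-c2c(Cl)cccc2Cl)c1COc1ccc2c(ccn2Cc2ccc(C(=O)O)cc2)c1`: 330 nM
compound 2 `CC(C)c1onc(-c2c(Cl)cccc2Cl)c1COc1ccc2c(ccn2S(=O)(=O)c2cccc(C(=O)O)c2)c1`: 1300 nM

Within the data shown here, in an assay on CV-1 cells with Bile acid receptor (Homo sapiens) as the target, read by a luciferase reporter (on this read-out higher numbers stand for an effect only at larger amounts of compound and lower numbers for an effect already at smaller amounts), compound 2 stands highest of the two numbers, and the only measured step, a 3.9-fold higher number from compound 1 to compound 2 (0.60 log units; beyond the scatter), goes with a change of the group on the aromatic nitrogen. Compound 3 `CC(C)c1onc(-c2c(Cl)cccc2Cl)c1COc1ccc2c(ccn2C(=O)c2cccc(C(=O)O)c2)c1` differs from compound 2 by (3-carboxyphenyl)carbonyl in place of (3-carboxyphenyl)sulfonyl on an aromatic nitrogen. No measured step sets a carbonyl against a sulfonyl at this position; the one step shown only indicates that swapping the group on this nitrogen moves the read-out by a modest amount. The expected step is a 1.4-fold lower number from compound 2 to compound 3 (0.16 log units; within the scatter), not clearly beyond the scatter. Compound 3 is therefore estimated at 900 nM, within 300 nM to 2700 nM.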

Compound 3, half-maximal effective concentration: 860 nM
Compound 3: middle estimate off by 1.0-fold (0.02 log units), on the high side, and the stated range covers the measured number.
By their numbers in this assay, from the lowest: compound 1; then compounds 3 and 2 (each within the scatter of the next).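

Carbonyl in place of sulfonyl on the aromatic nitrogen, with the 3-carboxyphenyl part kept, gives a 1.5-fold lower number from compound 2 to compound 3 (0.18 log units; within the scatter) in this assay, so the two groups are not separated on this read-out. Against 4-carboxybenzyl, the (3-carboxyphenyl)carbonyl group gives a 2.6-fold higher number from compound 1 to compound 3 (0.42 log units; beyond the scatter), so neither 3-carboxyphenyl compound matches compound 1. No supporting data explain either step.

The step from compound 1 changes both the group joining the aromatic nitrogen to the ring and the location of the carboxylic acid. A 3-carboxybenzyl group on this nitrogen would separate those two changes.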